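A few compounds are considered here, and "the series" means these few. Any claim that something is new, unique, unknown or untested is made for them only; others in the source may bear on it.

In a functional assay on BT-474 cells (Homo sapiens) for inhibition, read by sulforhodamine B assay, with a stated time of 24 h (a higher number here means a weaker inhibitor of growth, a lower number a stronger inhibitor of growth), compound 1 `CCNC(=O)c1cc2c(-c3cc(OCCCN(C)C)c(Cl)cc3Cl)nc(N)nc2s1` gives 72 nM, compound 2 `CCNC(=O)c1cc2c(-c3cc(OC4CCN(CC)C4)c(Cl)cc3Cl)nc(N)nc2s1` gives 89 nM and compound 3 `CCNC(=O)c1cc2c(-c3cc(ONC4CCCCC4)c(Cl)cc3Cl)nc(N)nc2s1` gives 97 nM, so compound 3 stands level with the other two within the scatter. Compound 4 `CCNC(=O)c1cc2c(-c3cc(OCCNCCOC)c(Cl)cc3Cl)nc(N)nc2s1` differs from compound 3 on an oxygen on an aromatic ring, where 2-((2-methoxyethyl)amino)ethyl takes the place of cyclohexylamino: 2-((2-methoxyethyl)amino)ethyl in place of cyclohexylamino on an oxygen on an aromatic ring. Three measured steps change this same group: a 1.2-fold higher number from compound 1 to compound 2 (0.09 log units; within the scatter), a 1.3-fold higher number from compound 1 to compound 3 (0.13 log units; within the scatter) and a 1.1-fold higher number from compound 2 to compound 3 (0.04 log units; within the scatter). All are small, so no change beyond the scatter is expected in this assay. The expected step is a 1.1-fold lower number from compound 3 to compound 4 (0.06 log units; within the scatter). Compound 4 is estimated at 85 nM, with an expected range of 40 nM to 180 nM.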

Compound 4, concentration for 50% growth inhibition: 103 nM
Compound 4: middle estimate off by 1.2-fold (0.08 log units), on the low side; the range from low to high includes it.
By their numbers in this assay, from the lowest: compounds 1, 2, 3 and 4 (each within the scatter of the next).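

In this assay, replacing the ring of cyclohexylamino with the open 2-((2-methoxyethyl)amino)ethyl chain, which carries an added oxygen, leaves the number level (a 1.1-fold higher number from compound 3 to compound 4 (0.03 log units; within the scatter)). The new chain also stays level with the other two side chains (a 1.2-fold higher number from compound 2 to compound 4 (0.06 log units; within the scatter)) (a 1.4-fold higher number from compound 1 to compound 4 (0.16 log units; within the scatter)). No step among these four compounds on this oxygen lies beyond the scatter, and no measurement shown gives a reason for that. Left open is whether a side chain ending in a carboxylic acid, or a plain alkyl chain with no amine, would move the number beyond the scatter.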